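This account rests on a few compounds, and the source may have more. Where it says the series, first, only, none or still open, it means among the compounds named here.

Measured so far:
compound 1 `Nc1nc(Cl)c2ncn(Cc3ccc(CCl)cc3)c2n1` gives 31000 nM
compound 2 `ClCc1cccc(Cn2cnc3ncnc(Cl)c32)c1` gives 18200 nM

In a functional assay on SK-MEL-5 cells (Homo sapiens) for cytotoxicity, read by sulforhodamine B assay, with a stated time of 48 h (a lower number here means a stronger inhibitor of growth, a higher number a weaker inhibitor of growth), compound 2 shows the lowest of the two numbers recorded, with compound 1 as its nearest neighbour; the gap between the two lies within the scatter of repeat measurements, so no order of growth inhibition can be read from them. Compound 3 `ClCc1cccc(Cn2cnc3nc(Cl)nc(Cl)c32)c1` is the next compound of the series and has not yet been measured. It differs from compound 2 in one place: chloro in place of hydrogen on an aromatic carbon. The core of compound 2 is otherwise kept, as is the substituted benzyl group.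

Among the measured compounds shown here, no step between measured compounds is available to calibrate this exchange, and the two measured values themselves do not differ beyond the scatter. For compound 3 the expectation in this assay is therefore a step of modest size at most, a little toward stronger growth inhibition, though a result indistinguishable from compound 2 within the scatter is equally plausible. The expected step of a 1.5-fold lower number from compound 2 to compound 3 (0.18 log units; within the scatter) rests on nothing more than that outlook. Compound 3 is estimated at 12000 nM, with a range from 4000 nM to 40000 nM.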

Compound 3, concentration for total growth inhibition: 2450 nM
Estimate against measurement, compound 3: 4.9-fold (0.69 log units) above; measured number outside the range, below it.
By their numbers in this assay, from the lowest: compound 3; then compounds 2 and 1 (each within the scatter of the next).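

In this assay, among the compounds shown here, one chloro on the aromatic carbon between two ring nitrogen atoms gives a 7.4-fold lower number from compound 2 to compound 3 (0.87 log units; beyond the scatter), the first step that lies beyond the scatter. This position on the core therefore responds to a single heavy atom while the rest of compound 2 is kept, something the gap between compound 1 and compound 2 could not show, as it gave no order of growth inhibition. The data shown give no measured explanation for the size of this step.

For the compounds shown here, with only one exchange at this carbon, it remains open whether the step is specific to chloro or would also appear with another group there, such as bromo, methyl or methoxy. It also remains open whether the same exchange would give a step of similar size with the chloromethyl group placed elsewhere on the benzyl ring, since no pair among the compounds shown tests this.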